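Replacing nitro with dimethylsulfamoyl on compound 2

A few compounds are considered here, and "the series" means these few. Any claim that something is new, unique, unknown or untested is made for them only; others in the source may bear on it.

compound 1 `CCOc1ccc([N+](=O)[O-])cc1-c1ncc(C(=O)O)c(=O)[nH]1`: 25 mg/kg
compound 2 `CCOC(=O)c1cnc(-c2cc([N+](=O)[O-])ccc2OCC)[nH]c1=O`: 5 mg/kg

In a functional assay on the whole organism (strain Sprague-Dawley) for inhibition, with Rattus norvegicus as the target, with a stated time of 10 min (on this read-out higher numbers stand for an effect only at larger amounts of compound and lower numbers for an effect already at smaller amounts), compound 2 gives the lower of the two numbers, 5 mg/kg. Compound 3 `CCOC(=O)c1cnc(-c2cc(S(=O)(=O)N(C)C)ccc2OCC)[nH]c1=O` carries dimethylsulfamoyl in place of nitro on an aromatic carbon, para to an ethoxy group: dimethylsulfamoyl in place of nitro on an aromatic carbon. Among the compounds with values here, the only measured step, a 5.0-fold lower number from compound 1 to compound 2 (0.70 log units; beyond the scatter), lies at another place and was modest. Within the data shown here, no measured step covers this change, so its direction stays open and only a small shift is expected. Expected in this assay is a 1.6-fold higher number from compound 2 to compound 3 (0.20 log units; within the scatter). For compound 3 the estimated value is 8 mg/kg, with an expected range of 2 mg/kg to 30 mg/kg.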

Compound 3, dose for 50% inhibition: 50 mg/kg
Estimate against measurement, compound 3: 6.3-fold (0.80 log units) below; the measured number lies above the stated range.
By their numbers in this assay, from the lowest: compound 2; then compounds 1 and 3 (each within the scatter of the next).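

With the ethyl ester held constant, the aromatic carbon para to an ethoxy group proves sensitive in this assay: dimethylsulfamoyl in place of nitro gives a 10-fold higher number from compound 2 to compound 3 (1.00 log units; beyond the scatter). Within the data shown here, the earlier pair varied only the ester end, so this is the first sign that the group at this position also moves the dose. No available data explain this step. Still open, from the compounds shown here alone, is whether an amine or a nitrile at this position would stay close to compound 2. Also open, going by these compounds, is whether the carboxylic acid form would respond to dimethylsulfamoyl in the same way.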